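The compounds below may be only part of what the source reports. "The series", "measured", "known", "first", "only" and "open" are said of these compounds alone.

Compound 1 `CNC(=O)/C=C/CN1CC(Oc2ccc(Oc3c(-c4ccc(F)cc4)sc4cc(O)ccc34)cc2)C1`, compound 2 `CNC(=O)/C=C/CNCCOc1ccc(Oc2c(-c3ccc(F)cc3)sc3cc(O)ccc23)cc1` and compound 3 `C/C=C/C(=O)NCCOc1ccc(Oc2c(-c3ccc(F)cc3)sc3cc(O)ccc23)cc1` share a core and differ in the group on an oxygen on an aromatic ring. In a functional assay on MCF7 cells (Homo sapiens) for antiproliferative activity, read by CCK-8 assay, with a stated time of 48 h (a higher number here means a weaker inhibitor, a lower number a stronger inhibitor), compound 2 gives 16100 nM and compound 3 gives 21700 nM. These two sit together, with a 1.3-fold higher number from compound 2 to compound 3 (0.13 log units; within the scatter). Compound 1 reaches only a limit of the assay, > 25000 nM.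

Compound 4 `C=C(C)C(=O)N1CC(Oc2ccc(Oc3c(-c4ccc(F)cc4)sc4cc(O)ccc34)cc2)C1` carries 1-((1-methylethenyl)carbonyl)azetidin-3-yl in place of the 2-(((prop-1-en-1-yl)carbonyl)amino)ethyl of compound 3, on an oxygen on an aromatic ring: 1-((1-methylethenyl)carbonyl)azetidin-3-yl in place of 2-(((prop-1-en-1-yl)carbonyl)amino)ethyl on an oxygen on an aromatic ring. The nearest measured comparisons are those between the azetidin-3-yl group of compound 1 and the open chains, an at least 1.1-fold lower number from compound 1 to compound 3 (0.06 log units; that floor lies within the scatter) and an at least 1.5-fold lower number from compound 1 to compound 2 (0.19 log units; that floor lies within the scatter). Both rest on a limit, and neither floor clears the scatter. For the measured compounds named here, no measured step here goes beyond the scatter, so no step beyond it is expected in this assay. A limit reading for compound 4 is also possible, given that compound 1, with its azetidin-3-yl group, stands at the limit of > 25000 nM in this assay, at which 1 of the 3 values shown sits. The expected change is small, an estimated 1.0-fold higher number from compound 3 to compound 4 (0.01 log units; within the scatter). Compound 4 is estimated at 22000 nM, with an expected range from 11000 nM to 40000 nM.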

Compound 4, half-maximal inhibitory concentration: > 25000 nM
Compound 4: only a limit was reported; the forecaster's own chance of this, stated with the estimate: 40%; middle value at least 1.1-fold (0.05 log units) from the limit.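

In this assay compound 4 gives only a limit, > 25000 nM, so with a carbonyl-bearing group on the ring nitrogen the azetidin-3-yl compound stands where compound 1 stands, and both listed compounds with this ring now share one reading: the limit of > 25000 nM in this assay, at which 2 of the 4 values shown sit. Leaving the open chain on this oxygen for 1-((1-methylethenyl)carbonyl)azetidin-3-yl gives an at least 1.1-fold higher number from compound 3 to compound 4 (0.06 log units; that floor lies within the scatter), and measured against the other open chain it gives an at least 1.5-fold higher number from compound 2 to compound 4 (0.19 log units; that floor lies within the scatter), so both steps rest on a limit and neither shows a change beyond the scatter. The step between the two ring compounds cannot be read, and the two different groups on the ring nitrogen therefore cannot be told apart in this assay.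

As far as these compounds go, how far the two azetidin-3-yl compounds lie past the limit stays open, and so does whether the ring itself matters, since the floors of the steps to it do not clear the scatter. Also open, from the compounds shown here alone, is whether a pyrrolidine or piperidine ring, or a longer chain ending in an amine, on this oxygen would give a number rather than a limit.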